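The source may report more compounds than this note shows. Statements on the series, on what has been measured and on what is new or still open speak of the compounds shown alone.

Measured in a functional assay on HL60/MX2 cells (Homo sapiens) for antiproliferative activity, read by MTT assay, with a stated time of 48 h; on this read-out lower numbers stand for stronger inhibition and higher numbers for weaker inhibition:
- Compound 1 `CCN(CC)CCn1c(N)c(-c2nc3ccccc3[nH]2)c2nc(C#N)c(C#N)nc21`: 7150 nM
- Compound 2 `CCCn1c(N)c(-c2nc3ccccc3[nH]2)c2nc(C#N)c(C#N)nc21`: > 50000 nM, a limit of the assay
- Compound 3 `CCN(CC)CCCn1c(N)c(-c2nc3ccccc3[nH]2)c2nc(C#N)c(C#N)nc21`: 1820 nM

Compound 3 gives the lower of the two actual numbers in this assay, and compound 1 is its nearest neighbour, with a 3.9-fold lower number from compound 1 to compound 3 (0.59 log units; beyond the scatter). The value of compound 2 is only a limit.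

Compound 4 `N#Cc1nc2c(-c3nc4ccccc4[nH]3)c(N)n(CCCO)c2nc1C#N` has hydroxy in place of diethylamino on a saturated chain carbon, three bonds along the chain from an aromatic nitrogen. The 3-(diethylamino)propyl group of compound 3 thus becomes 3-hydroxypropyl. Among the compounds with values here, the closest precedent is the step that adds diethylamino at this same place, an at least 27-fold lower number from compound 2 to compound 3 (1.43 log units; beyond the scatter). The shorter chain gives a similar picture, with an at least 6.9-fold higher number from compound 1 to compound 2 (0.84 log units; beyond the scatter) when diethylamino is replaced by methyl. Within the data shown here, no measured compound carries hydroxy, so the size of the change remains uncertain, and compound 4 might also return only a limit. A large rise in the number is expected, an estimated 11-fold higher number from compound 3 to compound 4 (1.04 log units; beyond the scatter). For compound 4, the estimated value is 20000 nM, with an expected range of 6000 nM to 60000 nM.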

Compound 4, half-maximal inhibitory concentration: > 50000 nM
Compound 4: no number, only a limit; the forecaster's own chance of this, stated with the estimate: 35%; middle value at least 2.5-fold (0.39 log units) away from the limit.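

In this assay, hydroxy on a saturated chain carbon, three bonds along the chain from an aromatic nitrogen, does not stand in for diethylamino, giving an at least 27-fold higher number from compound 3 to compound 4 (1.43 log units; beyond the scatter). The comparison with the shorter chain, where 2-(diethylamino)ethyl gives way to 3-hydroxypropyl, points the same way, with an at least 6.9-fold higher number from compound 1 to compound 4 (0.84 log units; beyond the scatter). Among the compounds shown, only those carrying diethylamino give a number, and a terminal hydroxy proves no better in this respect than the plain propyl chain, although the step between these two cannot be read because both stand at a limit of the assay: the limit of > 50000 nM in this assay, at which 2 of the 4 values shown sit.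

From the compounds shown here alone, how much of the effect depends on the amine itself remains open, since dimethylamino or a piperidine on the propyl chain would be needed to show it. Whether a butyl chain ending in diethylamino would lower the number further is also unresolved.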